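This account rests on a few compounds, and the source may have more. Where it says the series, first, only, none or still open, it means among the compounds named here.

Three compounds share one core and differ only in the group carried on an aromatic carbon of a six-membered aromatic ring of carbon only. Compound 1 `Cc1nc(-c2ccc(F)cc2)sc1COc1ccc2c(c1)OCC2CC(=O)O` carries fluoro there, compound 2 `Cc1nc(-c2ccc(Cl)cc2)sc1COc1ccc2c(c1)OCC2CC(=O)O` chloro, and compound 3 `Cc1ccc(-c2nc(C)c(COc3ccc4c(c3)OCC4CC(=O)O)s2)cc1` methyl. In an assay on CHO cells for agonist activity at Free fatty acid receptor 1 (Homo sapiens), read by FLIPR (a higher number here means that more compound is needed for the effect, a lower number that less compound is needed), compound 1 gives 79 nM, compound 2 gives 105 nM, and compound 3 gives 94 nM. The steps between them are small: a 1.3-fold higher number from compound 1 to compound 2 (0.12 log units; within the scatter), a 1.2-fold higher number from compound 1 to compound 3 (0.08 log units; within the scatter) and a 1.1-fold lower number from compound 2 to compound 3 (0.05 log units; within the scatter), each within the scatter, so compound 3 stands among the others and is not set apart from either of them.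

Compound 4 `COc1ccc(-c2nc(C)c(COc3ccc4c(c3)OCC4CC(=O)O)s2)cc1` keeps the core and differs from compound 3 in one place: methoxy in place of methyl on an aromatic carbon. Going by the values given here, no measured pair swaps methyl for methoxy, so the only guide is the set of three small steps, which show that fluoro, chloro and methyl on this carbon give numbers within the scatter of one another. Taking that as the guide, compound 4 is expected to stay close to compound 3, with a step of a 1.1-fold higher number from compound 3 to compound 4 (0.03 log units; within the scatter) in this assay. Compound 4 is therefore estimated at 100 nM in this assay, with a range from 40 nM to 250 nM.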

Compound 4, half-maximal effective concentration: 156 nM
Estimate against measurement, compound 4: 1.6-fold (0.19 log units) below, and the stated range covers the measured number.
By their numbers in this assay, from the lowest: compounds 1, 3, 2 and 4 (each within the scatter of the next).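

In this assay, going by these compounds alone, methoxy on this carbon sets compound 4 apart from none of the earlier compounds: the steps read a 1.7-fold higher number from compound 3 to compound 4 (0.22 log units; within the scatter) and a 1.5-fold higher number from compound 2 to compound 4 (0.17 log units; within the scatter) and a 2.0-fold higher number from compound 1 to compound 4 (0.30 log units; within the scatter) in turn, so even the widest of them, coming from fluoro, stays inside the usual spread of repeat measurements. The earlier compounds shown here showed only that fluoro, chloro and methyl give numbers that cannot be told apart, whereas this change replaces methyl, with 1 heavy atom and no hydrogen-bond acceptor, by methoxy, with 2 heavy atoms and 1 hydrogen-bond acceptor, and the number still does not move beyond the scatter. The position para to a large group thus accepts a group with an oxygen in it in this assay, and nothing here explains why the four numbers lie so close together.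

From the compounds shown here alone, whether an amine, a carboxylic acid or a longer chain such as butoxy on this carbon would also stay within the scatter remains open. Also open, going by these compounds, is how methoxy would fare on the other carbons of this ring, since all four groups shown sit on the same carbon.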